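From Thiophen-2-yl to 1,2-Thiazol-5-yl: An Expected Step

The source may report more compounds than this note shows. Statements on the series, on what has been measured and on what is new or still open speak of the compounds shown alone.

Measured so far:
- compound 1, `c1ccc(-c2ccncc2)c(OCC2=NCCN2)c1`: < 100000 nM, a limit of the assay
- compound 2, `c1ccc(-c2cnccn2)c(OCC2=NCCN2)c1`: < 100000 nM, a limit of the assay
- compound 3, `c1csc(-c2ccccc2OCC2=NCCN2)c1`: 15.9 nM

In a functional assay for activation of Alpha-1D adrenergic receptor (Homo sapiens), read by calcium flux (on this read-out lower numbers stand for an effect already at smaller amounts and higher numbers for an effect only at larger amounts of compound), compound 3 gives 15.9 nM. For compound 1 the assay reports only a limit, < 100000 nM. For compound 2 the assay likewise reports only a limit, < 100000 nM. Within the data shown here, compound 3 thus stands alone as the one compound with a number; the two other values are limits, as the limit of < 100000 nM in this assay, at which 2 of the 3 values shown sit, states.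

Compound 4, `c1ccc(-c2ccns2)c(OCC2=NCCN2)c1`, differs from compound 3 in one place: 1,2-thiazol-5-yl in place of thiophen-2-yl on an aromatic carbon.

Among the measured compounds shown here, no measured step speaks clearly to this change. The step from compound 1 to compound 2, a step that the two limits leave unreadable from compound 1 to compound 2, cannot be read. The same holds for a step that the limit leaves unreadable from compound 1 to compound 3 and for a step that the limit leaves unreadable from compound 2 to compound 3. For the measured compounds named here, what is known is only that compound 3 carries a number where the others carry limits. Both rings here are five-membered and of equal size, so the expectation for compound 4 rests on the value of compound 3 alone, widened for the uncertainty.

Compound 4 is expected to give about 40 nM in this assay, most likely between 8 nM and 300 nM. This estimate means an expected step of a 2.5-fold higher number from compound 3 to compound 4 (0.40 log units; beyond the scatter), not clearly beyond the scatter.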

Compound 4, half-maximal effective concentration: 25.1 nM
Compound 4: the middle estimate sits 1.6-fold (0.20 log units) above what was measured; the range from low to high includes it.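

In this assay, placing 1,2-thiazol-5-yl where thiophen-2-yl stood gives a 1.6-fold higher number from compound 3 to compound 4 (0.20 log units; within the scatter), so the two compounds cannot be told apart on this read-out. This is the only readable step among the compounds shown, and it concerns a group on an aromatic carbon of a six-membered aromatic ring of carbon only: the entering five-membered ring has 2 hetero atoms and the leaving one has 1, yet the change stays inside the normal spread of repeated measurements. The steps to compound 4 from compound 1 and from compound 2 cannot be read, because those two compounds give only a limit and no number: the limit of < 100000 nM in this assay, at which 2 of the 4 values shown sit.

The compounds shown leave open whether sulfur in the five-membered ring matters, which a furan-2-yl group, with oxygen in its place, would help to test. They also leave open how this position would read with no aromatic ring on it at all, for example with a simple amine, a carboxylic acid or a longer alkyl chain.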